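This account rests on a few compounds, and the source may have more. Where it says the series, first, only, none or still open, it means among the compounds named here.

The measured compounds:

Compound 1, `Fc1ccc(C2=NN(C(=S)Nc3ccccc3)C(c3ccc4c(c3)OCCO4)C2)cc1`: 61200 nM
Compound 2, `CSc1ccc(C2=NN(C(=S)Nc3ccccc3)C(c3ccc4c(c3)OCCO4)C2)cc1`: 193000 nM
Compound 3, `S=C(Nc1ccccc1)N1N=C(c2ccccc2Br)CC1c1ccc2c(c1)OCCO2`: 195000 nM

In a functional assay on HCT-116 cells (Homo sapiens) for antiproliferative activity, read by MTT assay, with a stated time of 48 h (a higher number here means a weaker inhibitor of growth, a lower number a stronger inhibitor of growth), compound 1 gives the lowest of the three numbers, and its steps to both other compounds lie beyond the scatter. Compound 4, `S=C(Nc1ccccc1)N1N=C(c2cccc(Cl)c2)CC1c1ccc2c(c1)OCCO2`, has not yet been measured; it differs from compound 1 in one place: 3-chlorophenyl in place of 4-fluorophenyl on a carbon with a double bond to nitrogen. Among the measured compounds shown here, two measured steps bear on this change, since both also alter the aryl group on the carbon with a double bond to nitrogen. There was a 3.2-fold higher number from compound 1 to compound 2 (0.50 log units; beyond the scatter), and there was a 3.2-fold higher number from compound 1 to compound 3 (0.50 log units; beyond the scatter). Both departures from the 4-fluorophenyl of compound 1 thus gave a modest rise in the number, of the same size. On that basis a modest rise is also expected for compound 4, though the sparse record leaves its exact size uncertain. Compound 4 is therefore estimated to give 120000 nM in this assay, in a range from 50000 nM to 300000 nM. This estimate means a 2.0-fold higher number from compound 1 to compound 4 (0.29 log units; within the scatter).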

Compound 4, concentration for 50% growth inhibition: 138000 nM
Compound 4: middle estimate off by 1.2-fold (0.06 log units), on the low side, within the range that was stated.
By their numbers in this assay, from the lowest: compound 1; then compounds 4, 2 and 3 (each within the scatter of the next).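

In this assay the 3-chlorophenyl group is a third replacement for 4-fluorophenyl on this carbon, and it too gives a 2.3-fold higher number from compound 1 to compound 4 (0.35 log units; beyond the scatter) and leaves compound 1 the strongest inhibitor of growth of the four. The three replacements cannot be told apart, since the steps are a 1.4-fold lower number from compound 3 to compound 4 (0.15 log units; within the scatter) and a 1.4-fold lower number from compound 2 to compound 4 (0.15 log units; within the scatter), so in these compounds the 4-fluorophenyl group stands alone while the others sit at one level. Nothing available accounts for this pattern.

In the step to compound 4 both the halogen and its place on the ring change, so 3-fluorophenyl or 4-chlorophenyl would be needed to separate the two. From the compounds shown here alone, it also remains open how a phenyl ring carrying an amine or a carboxylic acid would behave on this carbon.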